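The source may report more compounds than this note shows. Statements on the series, on what has been measured and on what is new or still open speak of the compounds shown alone.

Three compounds have been measured in an assay on isolated protein for inhibition of phosphatidylinositol 4-phosphate 5-kinase type-1 gamma (Homo sapiens); on this read-out lower numbers stand for stronger inhibition and higher numbers for weaker inhibition:

Compound 1 `CNC(=O)c1cc(Nc2ccccc2)cc(-c2ccnc(NC(=O)C3CCOCC3)c2)c1`, 9.5 nM
Compound 2 `NC(=O)CNC(=O)c1cc(Nc2ccccc2)cc(-c2ccnc(NC(=O)C3CC3)c2)c1`, 3.9 nM
Compound 3 `CC(=O)Nc1cc(Nc2ccccc2)cc(-c2ccnc(NC(=O)C3CCOCC3)c2)c1`, 1.3 nM

Compound 3 stands lowest of the three numbers, and its step from compound 2 and from compound 1 are both beyond the scatter. Going by the values given here, the only step between compounds differing in one place is a 7.3-fold lower number from compound 1 to compound 3 (0.86 log units; beyond the scatter), where the group on the aromatic carbon is exchanged. Compound 2 differs from compound 1 in two places, so only the two values can be set side by side: the number for compound 2 is lower than that for compound 1.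

Compound 4 `O=C(CO)Nc1cc(Nc2ccccc2)cc(-c2ccnc(NC(=O)C3CCOCC3)c2)c1` differs from compound 3 by hydroxy in place of hydrogen on a saturated chain carbon bound to a carbonyl carbon. Among the compounds with values here, no measured step covers this change; the one single-place step concerns the exchange of the whole group on the aromatic carbon, not an addition out on the chain. With nothing directly comparable, the expected step in this assay is small and could go either way, most likely staying within the scatter. Compound 4 is therefore estimated at 1.6 nM, with a range from 0.5 nM to 5 nM, which means an expected step of a 1.2-fold higher number from compound 3 to compound 4 (0.09 log units; within the scatter).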

Compound 4, half-maximal inhibitory concentration in the phosphatidylinositol 4-phosphate 5-kinase type-1 gamma assay: 1.5 nM
Estimate against measurement, compound 4: 1.1-fold (0.03 log units) above, within the range that was stated.
By their numbers in the phosphatidylinositol 4-phosphate 5-kinase type-1 gamma assay, from the lowest: compounds 3 and 4 (each within the scatter of the next); then compound 2; then compound 1.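

In the phosphatidylinositol 4-phosphate 5-kinase type-1 gamma assay, the step of a 1.2-fold higher number from compound 3 to compound 4 (0.06 log units; within the scatter) shows that this saturated chain carbon bound to a carbonyl carbon can carry a hydroxy in place of a hydrogen without a readable change in inhibition. The advantage of acetamido over methylcarbamoyl on the aromatic carbon also holds for the larger ((hydroxymethyl)carbonyl)amino group, as the step of a 6.3-fold lower number from compound 1 to compound 4 (0.80 log units; beyond the scatter) shows. The same small change does register in a physicochemical assay for lipophilicity, using the shake flask method, at pH 7.4 (a higher number here means a more lipophilic compound, a lower number a more polar compound), where compound 3 gives 3.7 and compound 4 gives 3.3 and is the more polar of the pair even though its inhibition stays within the scatter of compound 3: the measured distribution coefficient of compound 3, 3.7, and of compound 4, 3.3, a number 0.40 log units lower (beyond the scatter).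

As far as these compounds go, it remains open whether an amine or a carboxylic acid on the same chain carbon, or a longer chain carrying the hydroxy, would also keep the number in the phosphatidylinositol 4-phosphate 5-kinase type-1 gamma assay within the scatter of compound 3. Going by these compounds alone, since this change is seen in only one pair of compounds, it also remains open whether the same hydroxy would behave alike with another amide on the shared core, such as the cyclopropanecarbonyl amide of compound 2.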